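Swapping fluorine for bromine on a phenyl thiol acid

The source may hold more compounds than are shown below. What is called first, only, known or untested is meant among the compounds shown, and "the series" means these compounds.

Compound 1 `O=C(O)/C(S)=C/c1cccc(F)c1` gives 19000 nM in an assay on isolated protein for inhibition of Calpain-1 catalytic subunit (Sus scrofa), read by FRET (on this read-out higher numbers stand for weaker inhibition and lower numbers for stronger inhibition), the highest of the three numbers measured. Compound 2 `O=C(O)/C(S)=C/c1c[nH]c2ccc(I)cc12` gives 100 nM and compound 3 `O=C(O)/C(S)=C/c1c[nH]c2ccc(Br)cc12` gives 6 nM in this assay; both carry a bicyclic core that compound 1 lacks. Compound 4 `O=C(O)/C(S)=C/c1cccc(Br)c1` differs from compound 1 by bromo in place of fluoro on an aromatic carbon. Among the measured compounds shown here, the only measured step that bears on it is a halogen-for-halogen swap on a different core: a 17-fold lower number from compound 2 to compound 3 (1.22 log units; beyond the scatter). That step points toward a lower number for a heavier-to-lighter halogen exchange, whereas here a lighter halogen is exchanged for a heavier one, so only a modest step is expected, a 2.4-fold lower number from compound 1 to compound 4 (0.38 log units; beyond the scatter). Compound 4 is estimated at 8000 nM, within 2000 nM to 30000 nM.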

Compound 4, half-maximal inhibitory concentration: 4000 nM
Beside the measured number, compound 4's estimate is 2.0-fold (0.30 log units) above it, and the stated range covers the measured number.
By their numbers in this assay, from the lowest: compound 3; then compound 2; then compound 4; then compound 1.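

On the core of compound 1, exchanging fluoro for bromo at this ring position changes the result beyond the usual scatter in this assay, with a 4.8-fold lower number from compound 1 to compound 4 (0.68 log units; beyond the scatter). Here the heavier halogen gives the lower number, whereas a 17-fold lower number from compound 2 to compound 3 (1.22 log units; beyond the scatter) shows the lighter halogen doing so in a different pair, so halogen size alone sets no single direction across these compounds. No measurement shown explains either step. Still open, going by these compounds, is how chloro or an amine at this same place would compare with bromo on the core of compound 1.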